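The compounds below may be only part of what the source reports. "The series", "measured", "known", "first", "only" and "open" are said of these compounds alone.

Measured compounds:
- compound 1, `COc1cc(C)cc(-c2c(-c3ccnc(-c4ccc(C(C)=O)cc4)c3)cnn2CC#N)c1`: 3570 nM
- compound 2, `COc1cc(C)cc(-c2nn(CC#N)cc2-c2ccc(-c3cccc(C(C)=O)c3)nc2)c1`: 2730 nM

In a functional assay on IGROV-1 cells (Homo sapiens) for inhibition, read by sulforhodamine B assay, with a stated time of 48 h (on this read-out higher numbers stand for weaker inhibition of growth and lower numbers for stronger inhibition of growth), compound 1 gives 3570 nM, the highest of the two numbers. Its nearest neighbour, compound 2, gives 2730 nM in this assay, a difference that stays within the scatter, so the two cannot be ordered against each other. Compound 3, `COc1cc(C)cc(-c2c(-c3ccnc(-c4ccc(N(C)C)cc4)c3)cnn2CC#N)c1`, has not yet been measured in this assay. It arises from compound 1 through (dimethylamino in place of acetyl on an aromatic carbon), that is, dimethylamino in place of acetyl on an aromatic carbon. Within the data shown here, no step between measured compounds touches this position, and the two measured values span only a narrow band, so nothing in the data points to a large shift in either direction. The change from compound 1 to compound 3 is therefore expected to be small, close to the scatter: a 1.2-fold lower number from compound 1 to compound 3 (0.08 log units; within the scatter). Compound 3 is estimated at 3000 nM, with a range from 1000 nM to 9000 nM in this assay.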

Compound 3, concentration for 50% growth inhibition: 60.8 nM
Beside the measured number, compound 3's estimate is 49-fold (1.69 log units) above it; the whole stated range lies above it.
By their numbers in this assay, from the lowest: compound 3; then compounds 2 and 1 (each within the scatter of the next).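

In this assay, among these compounds, the group on the six-membered aromatic ring of carbon only proves decisive, since dimethylamino in place of acetyl gives a 59-fold lower number from compound 1 to compound 3 (1.77 log units; beyond the scatter), a sensitivity at this position that no earlier compound had revealed. The two groups have the same heavy-atom count, the same donor and acceptor counts and no net charge, so these counts do not separate them here. The two compounds differ only in acetyl and dimethylamino. Nothing available gives a reason for the size of this step.

Whether dimethylamino is unique at this place remains open, as the compounds shown do not tell how a primary amine, a methoxy group or a pyrrolidine ring would read there. Nor do they tell whether the same exchange would carry over to the framework of compound 2.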